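Pyridin-4-yl in Place of a Small Chain on the Hydrazine

The source may report more compounds than this note shows. Statements on the series, on what has been measured and on what is new or still open speak of the compounds shown alone.

The measured compounds and their values:
compound 1 `CCOC(=O)NNC1=C(CC(=O)c2ccccc2)C(=O)CC(C)(C)C1`: 1%
compound 2 `CC1(C)CC(=O)C(CC(=O)c2ccccc2)=C(NNC(=N)N)C1`: 1%

Both compounds share the same core and differ only in the group carried on the amine nitrogen of the hydrazine. In a functional assay on the whole organism (Central nervous system, strain CF) for inhibition, with Mus musculus as the target, with a stated time of 15 min, at a dose of 500 mg/kg by the oral route (on this read-out lower numbers stand for less inhibition and higher numbers for more inhibition at the one dose given (going by the name of the read-out)), compound 1 gives 1%, and in this assay compound 2 gives 1%. The step of no change at the digits printed from compound 1 to compound 2 (within the scatter) shows that exchanging the group on that nitrogen left the read-out where it was. Compound 2 therefore stands level with compound 1 on the numbers shown, and neither compound's number can be called higher or lower than the other's.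

Compound 3 `CC1(C)CC(=O)C(CC(=O)c2ccccc2)=C(NNc2ccncc2)C1` is not yet measured. It differs from compound 2 by a group of 6 heavy atoms (5 carbon, 1 nitrogen; one six-membered aromatic ring with 1 hetero atom) in place of a group of 3 heavy atoms (1 carbon, 2 nitrogen; no ring), on an amine nitrogen. Going by the values given here, the only step that bears on this change is no change at the digits printed from compound 1 to compound 2 (within the scatter), which also exchanged the group on this amine nitrogen and produced nothing beyond the scatter. On that basis the step of a number 1 percentage points higher from compound 2 to compound 3 (within the scatter) is expected to be none beyond the scatter. For compound 3 in this assay the estimate is 2%, with a range from 0% to 15%.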

Compound 3, a percentage reported as inhibition, in the whole organism at one dose (the size of the read-out at that dose, not a potency): 1%
Beside the measured number, compound 3's estimate is 1 percentage points above it, within the range that was stated.
By their numbers in this assay, from the lowest: compounds 1, 2 and 3 (each within the scatter of the next).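

In this assay the exchange gives no change at the digits printed from compound 2 to compound 3 (within the scatter) and no change at the digits printed from compound 1 to compound 3 (within the scatter) once pyridin-4-yl sits on the amine nitrogen, so a six-membered aromatic ring at this position reads level with both ring-free groups. Going by these compounds alone, the earlier pair had compared only two groups without a ring, whereas this result extends the comparison to a ring and to a larger change in the group on this nitrogen, and still no step goes beyond the scatter. No separate measurement bears on this result, and what lies behind it cannot be told from the data shown.

The compounds shown leave open whether any group on this nitrogen can give a read-out beyond the scatter of these three, for example a carboxylic acid, a longer alkyl chain, a primary amine on a short chain, or phenyl in place of pyridin-4-yl. They also leave open whether pyridin-3-yl or pyridin-2-yl would read level with pyridin-4-yl, and how any of these groups would read at another dose or at another time after dosing.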